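A few compounds are considered here, and "the series" means these few. Any claim that something is new, unique, unknown or untested is made for them only; others in the source may bear on it.

Values in a functional assay on SMMC-7721 cells (Homo sapiens) for cytotoxicity, read by MTT assay, with a stated time of 4 days; a higher number here means a weaker inhibitor, a lower number a stronger inhibitor:
Compound 1, `C=C1C[C@]23C[C@@]1(O)CC[C@H]2c1cc(Br)c(O)c(C)c1[C@@H]3Cn1cc(-c2ccc(F)cc2)nn1`, only a limit of the assay: > 20000 nM.
Compound 2, `C=C1C[C@]23C[C@@]1(O)CC[C@H]2c1cc(Br)c(O)c(C)c1[C@@H]3Cn1cc(-c2ccc(C(F)(F)F)cc2)nn1`: 12800 nM.
Compound 3, `C=C1C[C@]23C[C@@]1(O)CC[C@H]2c1ccc(O)c(C)c1[C@@H]3Cn1cc(-c2ccc(C)cc2)nn1`, only a limit of the assay: > 20000 nM.

Compound 3 stands at a limit of this assay, so no number is known for it, only that it lies beyond the range measured. Two of the three values shown sit at that limit (the limit of > 20000 nM in this assay, at which 2 of the 3 values shown sit). The step to compound 4, `C=C1C[C@]23C[C@@]1(O)CC[C@H]2c1cc(Br)c(O)c(C)c1[C@@H]3Cn1cc(-c2ccc(C)cc2)nn1`, is bromo in place of hydrogen on an aromatic carbon. Among the measured compounds shown here, no measured step covers this change. For the measured compounds named here, the only step with a number, an at least 1.5-fold lower number from compound 1 to compound 2 (0.19 log units; that floor lies within the scatter), concerns the substituent on the other aryl ring, and both compound 1 and compound 2 already carry the bromo group that compound 4 gains, one of them at the limit and the other with a number not far from it. Going by the values given here, compound 2 is thus the only member of the series with a number at all. With nothing bearing on the change, the expectation for compound 4 is no step beyond the scatter. The step expected from compound 3 to compound 4 is a number no higher from compound 3 to compound 4 (the limit leaves the size open). Compound 4 is expected near 20000 nM, within 8000 nM to 60000 nM, and most likely again reported only as a limit in this assay.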

Compound 4, half-maximal inhibitory concentration: > 20000 nM
Compound 4: a limit, no number; the forecaster's own chance of this, stated with the estimate: 55%; the middle value lies on the limit itself.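

Bromo in place of hydrogen, on the aromatic carbon ortho to a hydroxy group, does not by itself bring the series into the measurable range of this assay: compound 4 gives > 20000 nM, a limit and not a number. The steps from compound 3 to compound 4 and from compound 1 to compound 4 cannot be read, and the change at this position therefore has no size, as each pair sits at the same limit: the limit of > 20000 nM in this assay, at which 3 of the 4 values shown sit. Among the compounds shown here, with bromo present throughout, methyl in place of trifluoromethyl gives an at least 1.5-fold higher number from compound 2 to compound 4 (0.19 log units; that floor lies within the scatter), so the only number remains that of the trifluoromethyl compound, and the floor of this step does not separate it from the scatter.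

Going by these compounds, whether bromo in place of hydrogen moves the value at all stays open, as this would take a pair with both members inside the range of this assay. Also open, on these data alone, is how an amine or a carboxylic acid would behave on the aromatic carbon that carries trifluoromethyl in compound 2.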